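The compounds below may be only part of what the source reports. "The series", "measured", "known", "first", "only" and "open" are said of these compounds alone.

Three measured compounds share one core and differ only in the groups attached to it. Compound 1 `CCS[C@@H]1[C@H](SCC)[C@@H](Cn2cc(-c3ccc(OC)cc3)nn2)O[C@H]1n1ccc(=O)[nH]c1=O` gives 16200 nM in a functional assay on HepG2 cells (Homo sapiens) for cytotoxicity, read by MTT assay, with a stated time of 72 h; on this read-out lower numbers stand for an effect already at smaller amounts and higher numbers for an effect only at larger amounts of compound. Compound 2 `CCS[C@@H]1[C@H](SCC)[C@@H](Cn2cc(-c3cccs3)nn2)O[C@H]1n1ccc(=O)[nH]c1=O` gives 91800 nM in this assay, and the step of a 5.7-fold higher number from compound 1 to compound 2 (0.75 log units; beyond the scatter) shows that exchanging the ring on the triazole carbon shifted the number clearly. Compound 3 `CCS[C@@H]1[C@H](SCC)[C@@H](Cn2cc(-c3ccc(OC)cc3)nn2)O[C@H]1n1cc(C)c(=O)[nH]c1=O` gives 22800 nM in this assay, and the step of a 1.4-fold higher number from compound 1 to compound 3 (0.15 log units; within the scatter) stays inside the scatter. On these three numbers compound 3 stands second highest, close to compound 1 and well apart from compound 2.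

Compound 4 `CCOC(=O)c1cn(C[C@H]2O[C@@H](n3cc(C)c(=O)[nH]c3=O)[C@H](SCC)[C@@H]2SCC)nn1` has not been measured. It differs from compound 3 in one place: ethoxycarbonyl in place of 4-methoxyphenyl on an aromatic carbon. Among the measured compounds shown here, the only measured step at that same position is a 5.7-fold higher number from compound 1 to compound 2 (0.75 log units; beyond the scatter), where one aromatic ring replaced another and the number rose by a modest amount. Here the ring leaves altogether and a small, non-ring ethoxycarbonyl enters, a larger alteration with no direct precedent among the measured compounds, so the direction is uncertain and the expected step is wider than the scatter. The expected change is a 2.0-fold higher number from compound 3 to compound 4 (0.30 log units; within the scatter). Compound 4 is therefore estimated at 45000 nM in this assay, with a range from 12000 nM to 160000 nM.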

Compound 4, half-maximal effective concentration: >= 100000 nM
Compound 4: no number, only a limit (the forecaster's own chance of this, stated with the estimate: 20%); at least 2.2-fold (0.34 log units) between middle value and limit.
By their numbers in this assay, from the lowest: compounds 1 and 3 (each within the scatter of the next); then compound 2. At a limit, above all of these: compound 4.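

In this assay compound 4 gives only a limit of the assay, >= 100000 nM, and not a number. The earlier exchange at this position put one aromatic ring in place of another, whereas an at least 4.3-fold higher number from compound 3 to compound 4 (0.64 log units; beyond the scatter) shows that a group with no ring, ethoxycarbonyl, also moves the number upward, so both exchanges away from 4-methoxyphenyl, including a 5.7-fold higher number from compound 1 to compound 2 (0.75 log units; beyond the scatter), raise it, and neither of these two pairs goes against that. How far the number rose in the new exchange cannot be said, as the reading for compound 4 is a limit and not a number: the limit of >= 100000 nM in this assay, at which 1 of the 4 values shown sits.

The compounds shown leave open whether the rise follows from losing the aromatic ring or from bringing in ethoxycarbonyl, a question that an unsubstituted phenyl ring, a carboxylic acid or a butyl chain on this same carbon could help to separate. Also open, from the compounds shown here alone, are whether ethoxycarbonyl acts the same way on the core of compound 1, which lacks the methyl group, and whether any group here gives a lower number than 4-methoxyphenyl.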